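This account rests on a few compounds, and the source may have more. Where it says the series, first, only, none or still open, it means among the compounds named here.

Measured compounds in a functional assay on MDA-MB-231 cells (Homo sapiens) for cytotoxicity, read by MTT assay, with a stated time of 72 h; on this read-out lower numbers stand for stronger inhibition and higher numbers for weaker inhibition:

compound 1, `CN1CCN(c2ccc(NC(=N)c3cc4cn[nH]c4cn3)cc2)CC1`: 47500 nM
compound 2, `N=C(Nc1ccccc1)c1cc2c(-c3ccccc3)n[nH]c2c(NC2CCCCC2)n1`: 1710 nM
compound 3, `CN1CCN(c2ccc(NC(=N)c3cc4c(-c5ccccc5)n[nH]c4c(NC4CCCCC4)n3)cc2)CC1`: 1500 nM

Compound 1 stands apart from the other two: against compound 2 it shows a higher number by a margin beyond the scatter, and against compound 3 likewise. Compound 2 and compound 3 differ from compound 1 in the core, and the difference between the two cores is not broken down here.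

Within the pair compound 3 and compound 2, one change is made: hydrogen in place of 4-methylpiperazin-1-yl on an aromatic carbon. The step that goes with it is a 1.1-fold higher number from compound 3 to compound 2 (0.06 log units; within the scatter), so on the core of compound 3 taking the piperazine away leaves the read-out essentially where it was.

Compound 4, `N=C(Nc1ccccc1)c1cc2cn[nH]c2cn1`, is not yet measured. It stands to compound 1 as compound 2 stands to compound 3: hydrogen in place of 4-methylpiperazin-1-yl on an aromatic carbon. The two place descriptions agree word for word, on an aromatic carbon of a six-membered aromatic ring of carbon only, para to a large group, so this is the same change, now carried out on the core of compound 1 instead of the core of compound 3.

The expectation for compound 4 rests on one prior instance only. For compound 1 to compound 4 a step of a 1.1-fold higher number from compound 1 to compound 4 (0.02 log units; within the scatter) is expected, because the step of a 1.1-fold higher number from compound 3 to compound 2 (0.06 log units; within the scatter) was within the scatter. Whether the core of compound 1 answers the change in the same way is not shown by any compound here, so the range is kept wide. Compound 4 is estimated at 50000 nM, between 20000 nM and 125000 nM.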

Compound 4, half-maximal inhibitory concentration: > 50000 nM
Compound 4: no number, only a limit (the forecaster's own chance of this, stated with the estimate: 20%); the middle value sits exactly at the limit.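

In this assay compound 4 gives > 50000 nM, which is a limit of the assay and not a number. The step for hydrogen in place of 4-methylpiperazin-1-yl is an at least 1.0-fold higher number from compound 1 to compound 4 (0.02 log units; that floor lies within the scatter), so only a floor on its size is known, and setting it beside the earlier step settles nothing: the same change on two cores in this assay, a 1.1-fold higher number (0.06 log units; within the scatter) from compound 3 to compound 2 and an at least 1.0-fold higher number (0.02 log units; that floor lies within the scatter) from compound 1 to compound 4; the limit leaves it open whether they differ. The result fits a change that stays as small on this core as on the core of compound 3, and it fits equally a larger step hidden past the limit, so carrying the change from one core to the other is neither confirmed nor refuted: the limit of > 50000 nM in this assay, at which 1 of the 4 values shown sits.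

The groups that the core of compound 3 carries beyond the core of compound 1 always appear together in the compounds shown, so what each contributes on its own remains open. Also open, on these data alone, is whether a different group on the same aromatic carbon, such as a dimethylamino group or a carboxylic acid, would move the read-out on either core, and whether any such effect would carry from one core to the other.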